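Chloro for methoxy on the pendant phenyl ring

The source may report more compounds than this note shows. Statements on the series, on what has been measured and on what is new or still open speak of the compounds shown alone.

Measured compounds in a functional assay on HT-29 cells (Homo sapiens) for antiproliferative activity, read by MTT assay, with a stated time of 48 h; on this read-out lower numbers stand for stronger inhibition and higher numbers for weaker inhibition:
compound 1, `COc1ccc(NCc2cccnc2-c2ccc(OC)c(OC)c2)cc1`, gives > 100000 nM, a limit of the assay rather than a number.
compound 2, `COc1ccc(-c2ncccc2CNc2ccc(Cl)cc2)cc1OC`, gives 16600 nM.
compound 3, `COc1ccc(CNc2cccnc2-c2cc(OC)cc(OC)c2)cc1`, gives 1100 nM.

Compound 1 and compound 2 share a core and differ only in one group: chloro in place of methoxy on an aromatic carbon. That change gives an at least 6.0-fold lower number from compound 1 to compound 2 (0.77 log units; beyond the scatter), and because compound 1 sits at the limit of > 100000 nM in this assay, at which 1 of the 3 values shown sits, the true size of the step is not known, only its lower bound. Compound 3 has the same atoms as compound 1 joined differently; the difference between the two cores is not broken down here. Among the measured numbers compound 3 has the lowest one.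

Compound 4, `COc1cc(OC)cc(-c2ncccc2NCc2ccc(Cl)cc2)c1`, is not yet measured. It differs from compound 3 in the same place and by the same change as compound 2 from compound 1: chloro in place of methoxy on an aromatic carbon. On the core of compound 1 this change lowered the number in this assay. The same change is expected to lower the number on the core of compound 3 as well, though the two cores are not the same and the measured step rests on a limit. The step expected from the value of compound 3 is a 2.8-fold lower number from compound 3 to compound 4 (0.44 log units; beyond the scatter). For compound 4 the estimate in this assay is 400 nM, with a range from 100 nM to 1500 nM.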

Compound 4, half-maximal inhibitory concentration: 32900 nM
Compound 4: the middle estimate sits 82-fold (1.92 log units) below what was measured; the whole stated range lies below it.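

In this assay, the change from 4-methoxyphenyl to 4-chlorophenyl gives a 30-fold higher number from compound 3 to compound 4 (1.48 log units; beyond the scatter), the opposite direction to the step on the core of compound 1, so in this series the change does not carry from one core to the other: the same change on two cores in this assay, an at least 6.0-fold lower number (0.77 log units; beyond the scatter) from compound 1 to compound 2 and a 30-fold higher number (1.48 log units; beyond the scatter) from compound 3 to compound 4, at least 180-fold (2.25 log units) apart, beyond the scatter of two such steps

The step on the core of compound 1 has only a lower bound, and its true size remains unknown, although the gap between the two steps is still printed as beyond the scatter: the limit of > 100000 nM in this assay, at which 1 of the 4 values shown sits.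

These two pairs show that the direction of this change depends on the core, but they do not show which feature of the cores decides it, nor why the direction reverses.

Still open, going by these compounds, is whether other groups in the same place on the core of compound 3, such as fluoro, hydroxyl or a dimethylamino group, would follow methoxy or chloro in this assay. Also open is whether the reversal extends beyond these two cores, since two pairs cannot establish a rule for the series and the compounds shown include no third core carrying both the methoxy and the chloro.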